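From 4-methoxyphenyl to benzyl on the ring nitrogen

This account rests on a few compounds, and the source may have more. Where it says the series, first, only, none or still open, it means among the compounds named here.

In a functional assay on DU-145 cells (Homo sapiens) for cytotoxicity, read by sulforhodamine B assay, with a stated time of 48 h (a higher number here means a weaker inhibitor of growth, a lower number a stronger inhibitor of growth), compound 3 (`COc1ccc(N2CCN(c3nc(Nc4ccc(C#N)c(C(F)(F)F)c4)nc(Oc4ccnc5ccccc45)n3)CC2)cc1`) reads > 100000 nM, which is a limit and not a number. Compound 1 (`N#Cc1ccc(Nc2nc(Oc3ccnc4ccccc34)nc(N3CCN(c4ccc(F)cc4)CC3)n2)cc1C(F)(F)F`) also gives only a limit, > 100000 nM. Compound 2 (`N#Cc1ccc(Nc2nc(Oc3ccnc4ccccc34)nc(N3CCN(c4cccc(C(F)(F)F)c4)CC3)n2)cc1C(F)(F)F`) gives a true number, 74100 nM. Compound 4 (`N#Cc1ccc(Nc2nc(Oc3ccnc4ccccc34)nc(N3CCN(Cc4ccccc4)CC3)n2)cc1C(F)(F)F`) differs from compound 3 thus: benzyl in place of 4-methoxyphenyl on an amine nitrogen in a ring. Three earlier swaps at this ring nitrogen bear on it. The first is an at least 1.3-fold lower number from compound 1 to compound 2 (0.13 log units; that floor lies within the scatter), and the second is an at least 1.3-fold higher number from compound 2 to compound 3 (0.13 log units; that floor lies within the scatter), both floors within the scatter. The third is a step that the two limits leave unreadable from compound 1 to compound 3. With these small or unreadable steps, no step beyond the scatter is expected in this assay. The expected step is an at least 1.1-fold lower number from compound 3 to compound 4 (0.04 log units; that floor lies within the scatter). For compound 4 the estimate is 90000 nM, with an expected range of 40000 nM to 200000 nM.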

Compound 4, concentration for total growth inhibition: > 100000 nM
Compound 4 ended at the assay's limit; the forecaster's own chance of this, stated with the estimate: 55%; at least 1.1-fold (0.04 log units) between middle value and limit.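

With benzyl on the ring nitrogen, in this assay compound 4 gives > 100000 nM and this is a limit, not a number. Within the data shown here, the one readable step is an at least 1.3-fold higher number from compound 2 to compound 4 (0.13 log units; that floor lies within the scatter) and the steps from compound 1 and compound 3 to compound 4 cannot be read. So benzyl, the first group here that is not a substituted phenyl, shows no readable gain in growth inhibition, and differences among these groups stay hidden: the limit of > 100000 nM in this assay, at which 3 of the 4 values shown sit.

Going by these compounds, how far apart compound 1, compound 3 and compound 4 truly lie stays open. Also open, on these data alone, is whether an amine, a carboxylic acid or a longer chain on this ring nitrogen would give a readable value.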